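This account rests on a few compounds, and the source may have more. Where it says the series, first, only, none or still open, it means among the compounds named here.

Working notes on the series:

- compound 1 `Cn1ncc(Cl)c1-c1cc(C(=O)N[C@@H]2CN[C@H](CCNS(C)(=O)=O)C[C@H]2c2ccc(F)c(F)c2)oc1Cl`: 920 nM
- compound 2 `Cn1ncc(Cl)c1-c1cc(C(=O)N[C@@H]2CN[C@H](CCN3CCC(O)CC3)C[C@H]2c2ccc(Cl)c(Cl)c2)oc1Cl`: 13700 nM
- compound 3 `CC(=O)NCC[C@@H]1C[C@@H](c2ccc(F)c(F)c2)[C@H](NC(=O)c2cc(-c3c(Cl)cnn3C)c(Cl)o2)CN1`: 920 nM

In a functional assay on HCT-116 cells (Homo sapiens) for antiproliferative activity, read by sulforhodamine B assay, with a stated time of 72 h (on this read-out lower numbers stand for stronger inhibition and higher numbers for weaker inhibition), compound 2 gives the highest of the three numbers, beyond the scatter from the other two. Compound 4 `Cn1ncc(Cl)c1-c1cc(C(=O)N[C@@H]2CN[C@H](CC(=O)NCC(O)CO)C[C@H]2c2ccc(Cl)c(Cl)c2)oc1Cl` has (2,3-dihydroxypropyl)carbamoyl in place of (4-hydroxypiperidin-1-yl)methyl on a saturated chain carbon bound to a saturated ring carbon. Going by the values given here, no measured step covers this exchange. The closest is acetyl in place of methylsulfonyl on an amine nitrogen, with no change at the digits printed from compound 1 to compound 3 (within the scatter). Compound 3 also carries an amide in its chain and gives 920 nM, but it differs from compound 2 elsewhere too. Support is therefore weak, and a move toward lower numbers in this assay is expected. The expected step is a 5.5-fold lower number from compound 2 to compound 4 (0.74 log units; beyond the scatter). For compound 4 the estimated value is 2500 nM, with an expected range of 600 nM to 10000 nM.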

Compound 4, half-maximal inhibitory concentration: 7090 nM
For compound 4 the middle estimate is 2.8-fold (0.45 log units) below the measured one; the measured number falls inside the stated range.
By their numbers in this assay, from the lowest: compounds 1 and 3 (each within the scatter of the next); then compounds 4 and 2 (each within the scatter of the next).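

At this position, on a saturated chain carbon bound to a saturated ring carbon, (2,3-dihydroxypropyl)carbamoyl in place of (4-hydroxypiperidin-1-yl)methyl gives a 1.9-fold lower number from compound 2 to compound 4 (0.29 log units; within the scatter) in this assay. The read-out therefore does not separate the ringed group from the open-chain one, despite their different donor and acceptor counts. No measurement at hand offers an explanation for this result. Still open, as far as these compounds go, is whether a carboxylic acid, a primary amine or a longer chain at this position would give a step beyond the scatter.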